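Trading a Nitrobenzoyl Ester for a Free Hydroxyl

The source may hold more compounds than are shown below. What is called first, only, known or untested is meant among the compounds shown, and "the series" means these compounds.

Compound 1 `COC(=O)/C(=C/Cn1c(-c2ccccc2)ncc(NC(=O)OCc2ccccc2)c1=O)COC(=O)c1ccc([N+](=O)[O-])cc1` was tested in a functional assay on cells (Colon cell line, Homo sapiens) for inhibition (on this read-out lower numbers stand for stronger inhibition and higher numbers for weaker inhibition), where compound 1 gives 7.6 ug/mL. Compound 2 `COC(=O)/C(=C/[C@H](C)NC(=O)Cn1c(-c2ccccc2)ncc(NC(=O)OCc2ccccc2)c1=O)COC(C)=O` gives 1.6 ug/mL in this assay, so compound 1 holds the higher of the two numbers, a gap beyond the usual scatter. For compound 3 `COC(=O)/C(=C/Cn1c(-c2ccccc2)ncc(NC(=O)N2CCN(C(C)=O)CC2)c1=O)COC(C)=O` only a limit is recorded in this assay, namely > 50 ug/mL.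

Compound 4 `COC(=O)/C(=C/Cn1c(-c2ccccc2)ncc(NC(=O)OCc2ccccc2)c1=O)CO` differs from compound 1 in one place: hydrogen in place of (4-nitrophenyl)carbonyl on an oxygen on a saturated carbon. Within the data shown here, no measured pair shows this kind of change, so the expectation rests on compound 1 alone. The expected step is a 1.3-fold higher number from compound 1 to compound 4 (0.12 log units; within the scatter), a shift within or barely beyond the scatter. Compound 4 is therefore estimated at 10 ug/mL, with a range from 3 ug/mL to 35 ug/mL.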

Compound 4, half-maximal inhibitory concentration: > 50 ug/mL
Compound 4 was reported as a limit (the forecaster's own chance of this, stated with the estimate: 15%); middle value at least 5.0-fold (0.69 log units) away from the limit.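

In this assay, this oxygen on a saturated carbon does not tolerate every change: going from the ((4-nitrophenyl)carbonyl)oxy group to hydroxy gives an at least 6.5-fold higher number from compound 1 to compound 4 (0.81 log units; beyond the scatter). The earlier compounds shown here could not show this, as all of them keep an ester here. The result for compound 4 is a limit of the assay, not a number: the limit of > 50 ug/mL in this assay, at which 2 of the 4 values shown sit.

Still open, from the compounds shown here alone, is whether the nitro group matters or the ester link alone. A plain benzoyl ester or a methyl ether on this oxygen, on the core of compound 1, would separate the two.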